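The source may hold more compounds than are shown below. What is called first, only, known or untested is meant among the compounds shown, and "the series" means these compounds.

Of the compounds shown here, three that share one core have been measured in a functional assay on SF-539 cells (Homo sapiens) for inhibition, read by sulforhodamine B assay, with a stated time of 48 h; a lower number here means a stronger inhibitor of growth, a higher number a weaker inhibitor of growth. Compound 1 `COc1cc(-c2nn(-c3cccc(NC(=O)c4ccc(Cl)c(C(F)(F)F)c4)c3)cc2-c2ccncc2)ccc1Cl` gives 4130 nM in this assay. Compound 2 `COc1cc(-c2nn(-c3cccc(NC(=O)Nc4ccc(Cl)c(C(F)(F)F)c4)c3)cc2-c2ccncc2)ccc1Cl` gives 1650 nM, and compound 3 `COc1cc(-c2nn(-c3cccc(NC(=O)c4ccccc4)c3)cc2-c2ccncc2)ccc1Cl` gives 387 nM. Compound 2 thus stands second highest of the three numbers, closer to compound 1 than to compound 3: the change in this assay was a 2.5-fold lower number from compound 1 to compound 2 (0.40 log units; beyond the scatter), and a 4.3-fold lower number from compound 2 to compound 3 (0.63 log units; beyond the scatter).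

Compound 4 `O=C(Nc1cccc(-n2cc(-c3ccncc3)c(-c3ccc(Cl)c(O)c3)n2)c1)Nc1ccc(Cl)c(C(F)(F)F)c1` differs from compound 2 at one place: hydrogen in place of methyl on an oxygen on an aromatic ring

Among the compounds with values here, the three measured steps all concern the group on the carbonyl carbon at the other end of the molecule; none of them touches the oxygen on the aromatic ring, so no measured step speaks directly to this change. With no evidence either way, the expected step in this assay from compound 2 to compound 4 is no change at the digits printed from compound 2 to compound 4 (within the scatter), which is within the scatter. Compound 4 is therefore estimated to give 1650 nM in this assay, with a range from 600 nM to 4500 nM.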

Compound 4, concentration for 50% growth inhibition: 782 nM
The estimate for compound 4 lay 2.1-fold (0.32 log units) above the measured number; the range from low to high includes it.
By their numbers in this assay, from the lowest: compound 3; then compound 4; then compound 2; then compound 1.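

Until now, every measured step concerned the group on the carbonyl carbon, so the oxygen on the aromatic ring at the other end of the molecule had not been tested in this assay. Replacing methoxy with hydroxy removes only the methyl, yet it gives a 2.1-fold lower number from compound 2 to compound 4 (0.32 log units; beyond the scatter), so this site also affects growth inhibition, and in this pair the hydroxy compound is the stronger inhibitor. No measurement at hand accounts for this step.

Going by these compounds, it remains open whether the shift depends on the free hydroxy itself or only on losing the methyl, a question that an amine at this place or a longer chain such as ethoxy could help answer. On these data alone, it is also open whether the same swap would give a similar step when the carbonyl carbon carries the phenyl of compound 3.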